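This account rests on a few compounds, and the source may have more. Where it says the series, first, only, none or still open, it means among the compounds named here.

Working notes on the series.

Of the compounds shown here, two have been measured in an assay on HEK293 cells for displacement of a labelled ligand from growth hormone secretagogue receptor type 1 (Homo sapiens), with a stated time of 60 min; on this read-out lower numbers stand for stronger inhibition and higher numbers for weaker inhibition. Compound 1 `COc1cccc(-n2cc3nc(-c4cccnc4C)n(C[C@H]4CCCN(CC5CCC5)C4)c(=O)c3n2)c1` carries a cyclobutyl group on the saturated chain carbon bound to the amine nitrogen in the ring; in this assay compound 1 gives 1.6 nM. Compound 2 `COc1cccc(-n2cc3nc(-c4cccnc4C)n(C[C@H]4CCCN(CC5CCCC5)C4)c(=O)c3n2)c1` carries a cyclopentyl group at the same place; in this assay compound 2 gives 12 nM. Among the compounds with values here, the only measured step so far is a 7.5-fold higher number from compound 1 to compound 2 (0.88 log units; beyond the scatter), so compound 2 stands at the higher of the two numbers and compound 1 at the lower.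

Compound 3 `COc1cccc(-n2cc3nc(-c4cccnc4C)n(C[C@H]4CCCN(CC5CCO5)C4)c(=O)c3n2)c1` is not yet measured. It differs from compound 2 in one place: oxetan-2-yl in place of cyclopentyl on a saturated chain carbon bound to an amine nitrogen in a ring. Within the data shown here, the one measured step that bears on this place is the change from cyclobutyl to cyclopentyl, a 7.5-fold higher number from compound 1 to compound 2 (0.88 log units; beyond the scatter), which shows that the size of the ring at this position moves the read-out. Compound 3 returns to a four-membered ring, now with one oxygen, so the number is expected to fall back toward that of compound 1 rather than stay at that of compound 2. The expected step for compound 3 is a 3.0-fold lower number from compound 2 to compound 3 (0.48 log units; beyond the scatter). On these data alone, the estimate for compound 3 in this assay is 4 nM, with a range from 1.5 nM to 12 nM; the oxygen in the ring is untested, so the range is kept wide.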

Compound 3, half-maximal inhibitory concentration: 23 nM
Estimate against measurement, compound 3: 5.8-fold (0.76 log units) below; measured number above the stated range.
By their numbers in this assay, from the lowest: compound 1; then compounds 2 and 3 (each within the scatter of the next).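

In this assay oxetan-2-yl in place of cyclopentyl gives a 1.9-fold higher number from compound 2 to compound 3 (0.28 log units; within the scatter) and so does not separate the two groups at this place, although one carries a four-membered ring with 1 hetero atom and the other a five-membered ring of carbon only. Oxetan-2-yl in place of cyclobutyl gives a 14-fold higher number from compound 1 to compound 3 (1.16 log units; beyond the scatter) in the same read-out, which shows that a four-membered ring on this saturated chain carbon does not by itself carry the low number of compound 1; among the three compounds, only the cyclobutyl group of compound 1 stands apart from the others. No supporting data bear on why the ring with oxygen reads as it does.

Open, on these data alone, is whether the gap between compound 1 and compound 3 belongs to the oxygen itself or to its place in the ring, a question that oxetan-3-yl or an azetidine ring bearing nitrogen in place of oxygen would address. Also open, as far as these compounds go, is how the read-out responds to a smaller carbon ring such as cyclopropyl or to an open chain such as isobutyl at this place.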